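The source may report more compounds than this note shows. Statements on the series, on what has been measured and on what is new or still open speak of the compounds shown alone.

Compound 1 `COC(C)(C)CCCC(C)C/C=C/C(C)=C/C(=O)SC` gives 6.24 in a physicochemical assay for lipophilicity; a higher number here means a more lipophilic compound, a lower number a more polar compound. Compound 2 `CCSC(=O)/C=C(C)/C=C/CC(C)CCCC(C)(C)OC` carries one more carbon than compound 1, and the change between them is methyl in place of hydrogen on a saturated chain carbon bound to a sulfur. In this assay compound 2 gives 6.78, so the step was a number 0.54 log units higher from compound 1 to compound 2 (beyond the scatter). Compound 3 `CCC(=O)/C=C(C)/C=C/CC(C)CCCC(C)(C)OC` has a different core; its difference from compound 1 is ethyl in place of methylsulfanyl on a carbonyl carbon, and in this assay compound 3 gives 5.07, the lowest of the three, a step of a number 1.17 log units lower from compound 1 to compound 3 (beyond the scatter). Compound 4 `CCCC(=O)/C=C(C)/C=C/CC(C)CCCC(C)(C)OC` is still to be measured. Going by the values given here, it differs from compound 3 by methyl in place of hydrogen on a saturated chain carbon, two bonds along the chain from a carbonyl carbon, which is the same kind of change as the one from compound 1 to compound 2, though the surroundings differ: in that earlier pair the new methyl sits on a saturated chain carbon bound to a sulfur, whereas here it sits on a saturated chain carbon, two bonds along the chain from a carbonyl carbon. Because the earlier step was a number 0.54 log units higher from compound 1 to compound 2 (beyond the scatter), a similar rise is expected, with a number 0.53 log units higher from compound 3 to compound 4 (beyond the scatter) as the estimated step. Compound 4 is therefore expected to give about 5.6 in this assay, most likely between 5.3 and 5.9.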

Compound 4, partition coefficient: 5.61
Compound 4: middle estimate off by 0.01 log units, on the low side; measured number inside the range.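

In this assay the added methyl gives a number 0.54 log units higher from compound 3 to compound 4 (beyond the scatter) and, on the core of compound 1, a number 0.54 log units higher from compound 1 to compound 2 (beyond the scatter) so this change carried over between the two cores with a similar step, even though the methyl sits in a different place in each: on a saturated chain carbon two bonds along the chain from a carbonyl carbon in one, and on a saturated chain carbon bound to a sulfur in the other. The two sulfur-bearing compounds still stay apart from compound 4, with propyl in place of ethylsulfanyl giving a number 1.17 log units lower from compound 2 to compound 4 (beyond the scatter) and propyl in place of methylsulfanyl giving a number 0.63 log units lower from compound 1 to compound 4 (beyond the scatter) so the added methyl does not bring the cores together. This is a single comparison of two steps, so it sets no rule for other cores, and nothing here tells why the two steps agree.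

A longer chain on the carbonyl carbon, such as butyl in place of propyl, might or might not continue the same rise. Going by these compounds, it also stays open how an amine or a carboxylic acid at that place would compare.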